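From an amide to an acid in a cytotoxicity assay

This account rests on a few compounds, and the source may have more. Where it says the series, first, only, none or still open, it means among the compounds named here.

Compound 1, `C=CC1=C(C(=O)NCCC)C(c2ccc(OC)c(OC)c2)OC1`, was tested in a functional assay on HeLa cells (Homo sapiens) for cytotoxicity, read by MTT assay, with a stated time of 24 h; on this read-out higher numbers stand for weaker inhibition and lower numbers for stronger inhibition. In this assay compound 1 gives only a limit of the assay, > 100000 nM. Compound 2, `C=CC1=C(C(=O)NCc2ccc(C)cc2)C(c2ccc(F)cc2)OC1`, likewise gives only a limit, > 100000 nM. Both values sit at the limit of > 100000 nM in this assay, at which 2 of the 2 values shown sit, so compound 1 stands at the edge of the measured range without a number of its own. Compound 3, `C=CC1=C(C(=O)O)C(c2ccc(OC)c(OC)c2)OC1`, differs from compound 1 by hydroxy in place of propylamino on a carbonyl carbon. Among the measured compounds shown here, no measured step covers such a change here, so no shift beyond the scatter is expected, and for compound 3 the expected step is a step that the limit leaves unreadable from compound 1 to compound 3. Compound 3 is expected to give around 150000 nM, between 60000 nM and 400000 nM, most likely again as a limit.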

Compound 3, half-maximal inhibitory concentration: 18000 nM
Estimate against measurement, compound 3: 8.3-fold (0.92 log units) above; measured number below the stated range.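

In this assay, putting hydroxy in place of propylamino on the carbonyl carbon gives an at least 5.5-fold lower number from compound 1 to compound 3 (0.74 log units; beyond the scatter), so this position can change the read-out, which compounds 1 and 2 alone could not show. Compound 1 gives only a limit, so the real size of the step stays unknown: the limit of > 100000 nM in this assay, at which 2 of the 3 values shown sit.

From the compounds shown here alone, it remains open whether the carboxy group itself matters or only the loss of the propylamino chain. A methyl ester or an unsubstituted amide on the same carbonyl carbon would help separate these two readings.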